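Adding a phenyl group to the benzyl ether of compound 1

The compounds below may be only part of what the source reports. "The series", "measured", "known", "first", "only" and "open" are said of these compounds alone.

Compound 1 `N[C@]1(C(=O)O)[C@H]2[C@@H](C[C@H]1OCc1ccccc1)[C@]2(F)C(=O)O` is the parent of this small series, carrying an unsubstituted benzyl ether on the shared core. In an assay on CHO cells for binding affinity to metabotropic glutamate receptor 2 (Rattus norvegicus) (on this read-out lower numbers stand for stronger inhibition and higher numbers for weaker inhibition), compound 1 gives 7.14 nM, the highest number of the three measured compounds. Compound 2 `N[C@]1(C(=O)O)[C@H]2[C@@H](C[C@H]1OCc1cccc(Cl)c1)[C@]2(F)C(=O)O` gives 3.28 nM and compound 3 `N#Cc1cccc(CO[C@@H]2C[C@@H]3[C@H]([C@]2(N)C(=O)O)[C@@]3(F)C(=O)O)c1` gives 2.94 nM. The two measured steps from compound 1 are a 2.2-fold lower number from compound 1 to compound 2 (0.34 log units; beyond the scatter) and a 2.4-fold lower number from compound 1 to compound 3 (0.39 log units; beyond the scatter); the pair compound 2 and compound 3 shows a 1.1-fold lower number from compound 2 to compound 3 (0.05 log units; within the scatter).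

Compound 4 `N[C@]1(C(=O)O)[C@H]2[C@@H](C[C@H]1OCc1ccccc1-c1ccccc1)[C@]2(F)C(=O)O` differs from compound 1 by phenyl in place of hydrogen on an aromatic carbon. Both measured changes to the benzyl ring, a chloro and a cyano, lowered the number modestly, but each was a small group, and nothing measured here shows what a second aromatic ring does at this place. The closest guidance therefore suggests at most a modest lowering, and the expectation for compound 4 is a 1.3-fold lower number from compound 1 to compound 4 (0.11 log units; within the scatter), with a wide range. Compound 4 is estimated at 5.5 nM, between 1.8 nM and 20 nM.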

Compound 4, inhibition constant: 4.07 nM
Beside the measured number, compound 4's estimate is 1.4-fold (0.13 log units) above it; measured number inside the range.
By their numbers in this assay, from the lowest: compounds 3, 2, 4 and 1 (each within the scatter of the next, the first and the last beyond it).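

In this assay the new step is a 1.8-fold lower number from compound 1 to compound 4 (0.24 log units; within the scatter), so phenyl, a whole second aromatic ring of 6 heavy atoms, can sit on this aromatic carbon, ortho to a large group, without moving the number beyond the scatter. Among the compounds shown here, the earlier changes to the benzyl ring were only chloro and cyano, so this is the first sign that the ring can carry a much larger group and stay within the scatter of compound 1. Nothing available here explains this result.

Still open, on these data alone, is what an amine, a carboxylic acid or a methyl group would do on this same carbon. Also open, as far as these compounds go, is whether a phenyl ring carrying its own chloro or nitrile would stay within the scatter of compound 4.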